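Replacing nitro with trifluoromethyl in compound 1

The compounds below may be only part of what the source reports. "The series", "measured", "known", "first", "only" and "open" are said of these compounds alone.

- compound 1 `Cc1cc(/C=C/C#N)cc(C)c1Oc1cc(Nc2ccc(C#N)cc2)c(N)cc1[N+](=O)[O-]` gives > 5 (a limit, not a number)
- compound 2 `COC(=O)c1cc(N)c(Nc2ccc(C#N)cc2)cc1Oc1c(C)cc(CCC#N)cc1C` gives 4.15
- compound 3 `Cc1cc(CCC#N)cc(C)c1Oc1cc(Nc2ccc(C#N)cc2)c(N)cc1C(N)=O` gives 2.65

All three results come from a physicochemical assay for lipophilicity, at pH 7.4; a higher number here means a more lipophilic compound, a lower number a more polar compound. Compound 1 stands at the limit of > 5 in this assay, at which 1 of the 3 values shown sits, and so has no exact number. Compound 4 `Cc1cc(/C=C/C#N)cc(C)c1Oc1cc(Nc2ccc(C#N)cc2)c(N)cc1C(F)(F)F` keeps the core of compound 1 and differs by one exchange trifluoromethyl in place of nitro on an aromatic carbon in which trifluoromethyl takes the place of nitro on an aromatic carbon, para to a (4-cyanophenyl)amino group.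

Within the data shown here, only one measured step is available, a number 1.50 log units lower from compound 2 to compound 3 (beyond the scatter) with amino in place of methoxy on a carbonyl carbon. Among the measured compounds shown here, that large step is a different exchange, so it shows only that a single small change can move this assay a long way. For the measured compounds named here, no measured pair tests nitro against trifluoromethyl.

Hydrogen-bond acceptors leave in this exchange and none enter, so the expected step is small and upward (a step that the limit leaves unreadable from compound 1 to compound 4), an estimate that starts from the limit of compound 1 with > 5 as its only anchor. For compound 4 the expected value is 5.3 with an estimated range from 4.7 to 5.9 in this read-out, and it may well be reported only as a limit.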

Compound 4, partition coefficient: > 5
Compound 4: only a limit was reported; the forecaster's own chance of this, stated with the estimate: 70%; the middle value is on the limit's open side.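

In this assay compound 4 gives > 5 as a limit, not a number. Among these compounds, compound 1 also gives > 5 as a limit, so no step between the two can be read: the limit of > 5 in this assay, at which 2 of the 4 values shown sit. The compounds shown leave open how far trifluoromethyl and nitro on this core differ in this assay here.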